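The source may report more compounds than this note shows. Statements on the series, on what has been measured and on what is new or still open speak of the compounds shown alone.

Measured so far:
Compound 1 `CN1CCC(c2ccc3c(c2)oc(=O)n3C(=O)NCCCCc2ccccc2)CC1=O`: 20000 nM.
Compound 3 `CCCCCNC(=O)n1c(=O)oc2cc(C3CCN(C)CC3)ccc21`: 240000 nM.
Compound 2 `CCN1CCN(c2ccc3c(c2)oc(=O)n3C(=O)NCCCCc2ccccc2)CC1`: < 1000 nM, which is a limit of the assay.

In a physicochemical assay for solubility, read by HPLC, in phosphate buffer, measured as kinetic solubility, with a stated time of 1 h, at pH 7.4, tested at 250 uM (on this read-out lower numbers stand for lower solubility and higher numbers for higher solubility), compound 1 gives 20000 nM and compound 3 gives 240000 nM. Compound 2 gives no number, only a limit, < 1000 nM, so it stands at the limit of < 1000 nM in this assay, at which 1 of the 3 values shown sits. Among the measured compounds shown here, the single measured step, an at least 20-fold lower number from compound 1 to compound 2 (1.30 log units; beyond the scatter), concerns the ring group on the aromatic carbon and not the group on the ring amine nitrogen. Compound 4 `CN1CCN(c2ccc3c(c2)oc(=O)n3C(=O)NCCCCc2ccccc2)CC1` differs from compound 2 by hydrogen in place of methyl on a saturated chain carbon bound to an amine nitrogen in a ring. For the measured compounds named here, no measured step covers such a change, so no shift beyond the scatter is expected, a step that the limit leaves unreadable from compound 2 to compound 4. Compound 4 is therefore expected at 800 nM, between 200 nM and 4000 nM, quite possibly again reported only as a limit.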

Compound 4, solubility: < 1000 nM
Compound 4: only a limit was reported; the forecaster's own chance of this, stated with the estimate: 65%; the middle value does not contradict the limit.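

With 4-methylpiperazin-1-yl in place of 4-ethylpiperazin-1-yl, this assay again returns a limit rather than a number, so the step between compound 2 and compound 4 cannot be read: the limit of < 1000 nM in this assay, at which 2 of the 4 values shown sit.

Replacing 1-methyl-2-oxopiperidin-4-yl with 4-methylpiperazin-1-yl gives an at least 20-fold lower number from compound 1 to compound 4 (1.30 log units; beyond the scatter), so the large drop seen with the ethyl-bearing ring recurs with the methyl-bearing ring. Where compound 2 and compound 4 truly sit remains open. Also open, as far as these compounds go, is how a piperazine ring with a 2-hydroxyethyl group or a carboxylic acid on its ring nitrogen would read in this assay.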